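Removing One Allyl Group from Compound 1

This account rests on a few compounds, and the source may have more. Where it says the series, first, only, none or still open, it means among the compounds named here.

- compound 1 `C=CCc1cc(-c2ccc(OC)cc2)cc(CC=C)c1O` gives 60300 nM
- compound 2 `C=CCc1ccc(OCCC)c(-c2ccc(OCCC)c(CC=C)c2)c1` gives > 114000 nM (a limit, not a number)

Within the data shown here, in a functional assay on Lewis lung carcinoma cells (Mus musculus) for antiproliferative activity, read by MTT assay, with a stated time of 24 h (on this read-out higher numbers stand for weaker inhibition and lower numbers for stronger inhibition), compound 1 gives 60300 nM, the only true number so far. Compound 2 reaches only a limit of the assay, > 114000 nM, so the two cannot be placed on one scale with any precision.

The next compound, compound 3 `C=CCc1cc(-c2ccc(OC)cc2)ccc1O`, changes compound 1 at one place: hydrogen in place of allyl on an aromatic carbon. This is hydrogen in place of allyl on an aromatic carbon, ortho to a hydroxy group.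

Among the measured compounds shown here, no measured pair shows what such a change does in this assay, so any forecast is uncertain. A small step towards weaker inhibition is expected, and it may stay within the usual scatter. The expected change is a 1.4-fold higher number from compound 1 to compound 3 (0.15 log units; within the scatter). For compound 3 the estimated value is 85000 nM, with an expected range from 40000 nM to 170000 nM.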

Compound 3, half-maximal inhibitory concentration: > 100000 nM
Compound 3 ended at the assay's limit (the forecaster's own chance of this, stated with the estimate: 25%); middle value at least 1.1-fold (0.07 log units) from the limit.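

In this assay compound 3 gives > 100000 nM, which is a limit of the assay and not a number. As far as these compounds go, putting hydrogen in place of the allyl group ortho to the hydroxy group gives an at least 1.6-fold higher number from compound 1 to compound 3 (0.21 log units; that floor lies within the scatter), and the true size of this step stays unknown because of a limit: the limit of > 100000 nM in this assay, at which 1 of the 3 values shown sits. Among these compounds, this is the first comparison here between compounds that differ in one place, and it shows that compound 1, with its allyl group at this position, gives a true number, while compound 3, with hydrogen there, does not.

From the compounds shown here alone, it remains open whether a shorter or longer chain than allyl, such as ethyl or butyl, or an amine at this position would give a true number in this assay. The compounds shown also leave open what the hydroxy group contributes on its own.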